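Ethoxy for methoxy on the free-amine chalcone

A few compounds are considered here, and "the series" means these few. Any claim that something is new, unique, unknown or untested is made for them only; others in the source may bear on it.

Compound 1 `C=C(Br)C(=O)Nc1ccc(/C=C/C(=O)c2ccc(OC)cc2)cc1` and compound 2 `C=C(Br)C(=O)Nc1ccc(/C=C/C(=O)c2ccc(OCC)cc2)cc1` carry the same acylated nitrogen and differ only by one carbon on the ether; compound 3 `COc1ccc(C(=O)/C=C/c2ccc(N)cc2)cc1` and compound 4 `CCOc1ccc(C(=O)/C=C/c2ccc(N)cc2)cc1` share that ether pair but have a free amine in its place.

In a functional assay on MOLT-4 cells (Homo sapiens) for antiproliferative activity, with a stated time of 48 h (on this read-out higher numbers stand for weaker inhibition and lower numbers for stronger inhibition), compound 1 gives 1300 nM, compound 2 gives 610 nM and compound 3 gives 19000 nM. The ether step is written as methyl in place of hydrogen on a saturated chain carbon bound to an oxygen on an aromatic ring and gives a 2.1-fold lower number from compound 1 to compound 2 (0.33 log units; beyond the scatter). The removal of the acyl group, (hydrogen in place of (1-bromoethenyl)carbonyl on a nitrogen on an aromatic ring), gives a 15-fold higher number from compound 1 to compound 3 (1.16 log units; beyond the scatter), so compound 3 sits well above both acylated compounds.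

The change from compound 3 to compound 4 is methyl in place of hydrogen on a saturated chain carbon bound to an oxygen on an aromatic ring. Its place is described in the same words as for the step from compound 1 to compound 2, so it is the same change, applied to a core that differs by the counted difference given above. Among the compounds with values here, with only one earlier example, on a different core, the expected direction is a modest lowering of the number, with wide uncertainty.

Compound 4 is expected to give 10000 nM in this assay, with a plausible range from 4000 nM to 25000 nM. Within the data shown here, this estimate rests on compound 1 and compound 2 because a 2.1-fold lower number from compound 1 to compound 2 (0.33 log units; beyond the scatter) is the only measured step of this kind. The expected step from compound 3 is a 1.9-fold lower number from compound 3 to compound 4 (0.28 log units; within the scatter).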

Compound 4, half-maximal inhibitory concentration: 11000 nM
Estimate against measurement, compound 4: 1.1-fold (0.04 log units) below; low and high end bracket the measured number.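

In this assay the methoxy to ethoxy change gives a 1.7-fold lower number from compound 3 to compound 4 (0.24 log units; within the scatter) on the free-amine core, and its size agrees with that on the acylated core: the same change on two cores in this assay, a 2.1-fold lower number (0.33 log units; beyond the scatter) from compound 1 to compound 2 and a 1.7-fold lower number (0.24 log units; within the scatter) from compound 3 to compound 4, 1.2-fold (0.09 log units) apart, within the scatter of two such steps. Replacing the (1-bromoethenyl)carbonyl group with hydrogen gives an 18-fold higher number from compound 2 to compound 4 (1.26 log units; beyond the scatter) in the ethoxy pair, and this large step also agrees with its counterpart in the methoxy pair: the same change on two cores in this assay, a 15-fold higher number (1.16 log units; beyond the scatter) from compound 1 to compound 3 and an 18-fold higher number (1.26 log units; beyond the scatter) from compound 2 to compound 4, 1.2-fold (0.09 log units) apart, within the scatter of two such steps. Within these four compounds the two changes therefore carry from one core to the other with no detectable dependence on each other, but this rests on a single pair of steps for each change, the ether step on the free-amine core alone cannot be told from scatter, and nothing here extends the result to other ether groups, other nitrogen substituents or other cells.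

The compounds shown leave open whether a longer chain on the oxygen, such as propoxy or butoxy, would extend the ether step, or whether a hydroxyl in that place would reverse it. They also leave open how much of the acyl step belongs to the bromine, which a plain acryloyl or acetyl group on the nitrogen would help to separate.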